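Bromine on a Phenyl Ring in a Thiazole Acetic Acid Series

The compounds below may be only part of what the source reports. "The series", "measured", "known", "first", "only" and "open" are said of these compounds alone.

Of the compounds shown here, three of this set have been measured. Compound 1 `COc1ccc(-c2nc(-c3ccc(Br)cc3)c(CC(=O)O)s2)cc1` was examined in an in vitro functional assay on HEK285-7 cells for antagonist activity at prostaglandin D2 receptor 2 (Homo sapiens), read by BRET and beta-arrestin recruitment; on this read-out higher numbers stand for larger maximal responses and lower numbers for smaller maximal responses. In this assay compound 1 gives > 70%, which is a limit of the assay and not a number. Compound 2 `COc1ccc(-c2nc(-c3ccccc3)c(CC(=O)O)s2)cc1` in this assay gives > 70%, again a limit rather than a number. Among the measured compounds shown here, compound 3 `O=C(O)Cc1sc(Cc2ccccc2)nc1-c1ccc(F)cc1` stands apart: in this assay compound 3 gives 30%, the only number among the three values. The difference between the core of compound 3 and the core of compound 2 is not broken down here.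

Compounds 2 and 1 differ in one place, (bromo in place of hydrogen on an aromatic carbon), and the step that the two limits leave unreadable from compound 2 to compound 1 cannot be sized, because the limit of > 70% in this assay, at which 2 of the 3 values shown sit, hides whatever change the bromo brought.

Compound 4 `O=C(O)Cc1sc(Cc2ccccc2Br)nc1-c1ccc(F)cc1` has not been measured. It differs from compound 3 by bromo in place of hydrogen on an aromatic carbon, the same kind of change as from compound 2 to compound 1, but the place is not the same: in compound 1 the bromo sits para to a large group, in compound 4 ortho to a large group, and the group carrying it is a benzyl rather than a phenyl. The measured step gives no usable size, so the expectation for compound 4 rests mainly on compound 3 and its value 30%, with room for the bromo to move the response either way. Compound 4 is estimated to reach 35% in this assay, spanning 15% to 60%, which corresponds to an expected step of a number 5 percentage points higher from compound 3 to compound 4 (within the scatter).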

Compound 4, largest response reached (reported as efficacy), in percent of the reference or control that the assay uses: > 70%
Compound 4 gave a limit, no number; the forecaster's own chance of this, stated with the estimate: 10%; middle value at least 35 percentage points from the limit.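

In this assay, the change from benzyl to 2-bromobenzyl gives a number at least 40 percentage points higher from compound 3 to compound 4 (beyond the scatter), so on the core of compound 3 this bromo goes with a large rise in maximal response, and its true size may be larger still. Compound 4 gives > 70%, which is a limit of the assay and not a number. This does not show that the change carries from one core to another, since the only other bromo pair, compound 2 and compound 1, sits on a different core with the bromo at a different place, its step cannot be read, and the comparison of the two cores ends at the ceiling of the read-out: the limit of > 70% in this assay, at which 3 of the 4 values shown sit.

The compounds shown leave open whether the rise belongs to bromo as such or would also come with chloro, methyl or an amine on the same benzyl, and whether a bromo elsewhere on that ring would act alike. They also leave open how the 2-bromobenzyl would read with a longer chain in place of the acetic acid, or with an amide in place of the carboxylic acid.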